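The compounds below may be only part of what the source reports. "The series", "measured", "known", "first", "only" and "open" are said of these compounds alone.

Three compounds share one core and differ only in the group carried on the amide-type nitrogen. Compound 1 `CC(C)(C)c1cc(C(=O)Nc2ccccn2)n(Cc2ccccc2)n1` gives 4.5 in a physicochemical assay for lipophilicity, read by HPLC, at pH 7.4; on this read-out lower numbers stand for lower lipophilicity and higher numbers for higher lipophilicity. Compound 2 `CC(C)(C)c1cc(C(=O)Nc2nc(CNS(C)(=O)=O)cs2)n(Cc2ccccc2)n1` gives 3.7 in this assay, and compound 3 `CNCc1csc(NC(=O)c2cc(C(C)(C)C)nn2Cc2ccccc2)n1` gives 3.8. Compound 3 stands second highest of the three numbers; its nearest neighbour is compound 2, within the scatter, and it lies furthest from compound 1. Compound 4 `CC(=O)NCc1csc(NC(=O)c2cc(C(C)(C)C)nn2Cc2ccccc2)n1` is not yet measured and differs from compound 3 by acetyl in place of methyl on an amine nitrogen, so that methylamino becomes acetamido. Going by the values given here, two measured steps bear on this. The closer one is the earlier exchange on the same amine nitrogen, a number 0.10 log units higher from compound 2 to compound 3 (within the scatter), which stayed within the scatter. The larger one, a number 0.70 log units lower from compound 1 to compound 3 (beyond the scatter), swapped the whole side group and is only loosely related. For compound 4 the change from methyl to acetyl is therefore expected to shift this assay only slightly, with no step beyond the scatter: no change at the digits printed from compound 3 to compound 4 (within the scatter). Compound 4 is estimated at 3.8, between 3.3 and 4.3.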

Compound 4, distribution coefficient: 3.3
Compound 4: middle estimate off by 0.50 log units, on the high side, and the stated range covers the measured number.
By their numbers in this assay, from the lowest: compound 4; then compounds 2 and 3 (each within the scatter of the next); then compound 1.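

On the amine nitrogen of this side group, the step of a number 0.10 log units higher from compound 2 to compound 3 (within the scatter) had shown no separation between methylsulfonyl and methyl in this assay, whereas acetyl in place of methyl gives a number 0.50 log units lower from compound 3 to compound 4 (beyond the scatter) and so shows that this position can respond to a change of group. Acetyl in place of methylsulfonyl gives a number 0.40 log units lower from compound 2 to compound 4 (beyond the scatter), which sets acetyl apart from both groups on the same nitrogen, even though those two remain within the scatter of each other. Nothing available explains why acetyl reads apart from them.

The compounds shown leave open where other groups on this nitrogen would fall, such as propionyl, benzoyl or a plain hydrogen that leaves a primary amine. They also leave open whether the acetyl step would recur with pyridin-2-yl's place on the amide-type nitrogen taken by a different side group.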